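Triazole nitrogen substituent: aryl versus benzimidazolylmethyl

A few compounds are considered here, and "the series" means these few. Any claim that something is new, unique, unknown or untested is made for them only; others in the source may bear on it.

Among the measured compounds shown here, in a functional assay on NCI-H460 cells (Homo sapiens) for antiproliferative activity, read by sulforhodamine B assay, with a stated time of 72 h (on this read-out higher numbers stand for weaker inhibition and lower numbers for stronger inhibition), compound 3 `CN(CCNCc1cn(Cc2nc3ccccc3[nH]2)nn1)CCNc1ccnc2cc(Cl)ccc12` gives 120000 nM, the highest number of the three measured members. Compound 1 `CN(CCNCc1cn(-c2ccc(F)cc2)nn1)CCNc1ccnc2cc(Cl)ccc12` gives 34000 nM and compound 2 `CN(CCNCc1cn(-c2cccc(Cl)c2)nn1)CCNc1ccnc2cc(Cl)ccc12` gives 17000 nM in this assay; a 2.0-fold lower number from compound 1 to compound 2 (0.30 log units; within the scatter). Against both of these compound 3 stands apart: a 3.5-fold higher number from compound 1 to compound 3 (0.55 log units; beyond the scatter) and a 7.1-fold higher number from compound 2 to compound 3 (0.85 log units; beyond the scatter).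

Compound 4 `CN(CCNCc1cn(-c2ccnc3cc(Cl)ccc23)nn1)CCNc1ccnc2cc(Cl)ccc12` differs from compound 3 in one place: 7-chloroquinolin-4-yl in place of (1H-benzimidazol-2-yl)methyl on an aromatic nitrogen. The two measured steps that bear on this change are those leading to compound 3, where the (1H-benzimidazol-2-yl)methyl group carried a higher number than either directly attached aryl ring. Compound 4 returns to a directly attached aromatic ring, so the change is expected to undo that rise in this assay, with a size in the range of the two steps seen, and direction toward a lower number.

For compound 4 the estimate in this assay is 15000 nM, expected between 4000 nM and 60000 nM, an expected step of an 8.0-fold lower number from compound 3 to compound 4 (0.90 log units; beyond the scatter).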

Compound 4, half-maximal inhibitory concentration: 16000 nM
The estimate for compound 4 lay 1.1-fold (0.03 log units) below the measured number; the range from low to high includes it.
By their numbers in this assay, from the lowest: compounds 4, 2 and 1 (each within the scatter of the next, the first and the last beyond it); then compound 3.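

In this assay, 7-chloroquinolin-4-yl in place of (1H-benzimidazol-2-yl)methyl on this aromatic nitrogen gives a 7.5-fold lower number from compound 3 to compound 4 (0.88 log units; beyond the scatter) and so shows that a group with two aromatic rings does not by itself carry the high number of compound 3. Against the single-ring groups, 7-chloroquinolin-4-yl gives a 1.1-fold lower number from compound 2 to compound 4 (0.03 log units; within the scatter) for 3-chlorophenyl and a 2.1-fold lower number from compound 1 to compound 4 (0.33 log units; beyond the scatter) for 4-fluorophenyl, a modest step. Among the four compounds, the three with a directly attached aromatic ring stand apart from compound 3, the only one with a methyl link to its ring system.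

A plain benzyl group would help to separate the methyl link from the hydrogen-bond donor of the leaving group, as the compounds shown change both together. No measurement shown accounts for any of these steps.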